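Chloropyridinylmethyl piperazine analogue: cytotoxicity outlook

A few compounds are considered here, and "the series" means these few. Any claim that something is new, unique, unknown or untested is made for them only; others in the source may bear on it.

The series shares one core, seen in compound 1 `CC(=O)N1CCC(C(=O)N(CCCN2CCC(Oc3ccccc3)CC2)c2ccc(C)c(Cl)c2)CC1`, compound 2 `CC(=O)N1CCC(C(=O)N(CCCN2CCN(Cc3ccncc3)CC2)c2ccc(C)c(Cl)c2)CC1` and compound 3 `CC(=O)N1CCC(C(=O)N(CCCN2CCC(CNc3ncccn3)CC2)c2ccc(C)c(Cl)c2)CC1`. In an ADME assay (Homo sapiens) for cytotoxicity (on this read-out higher numbers stand for lower toxicity in this test and lower numbers for higher toxicity in this test), compound 1 gives > 56600 nM, which is a limit of the assay and not a number. Compound 2 likewise gives only a limit in this assay, > 56700 nM. Compound 3 also reaches only a limit in this assay, > 55100 nM. Within the data shown here, the single measured step, a step that the two limits leave unreadable from compound 1 to compound 3, cannot be read, as both ends are limits (the limit of > 56600 nM in this assay, at which 1 of the 3 values shown sits, (the limit of > 55100 nM in this assay, at which 1 of the 3 values shown sits)). Compound 4 `CC(=O)N1CCC(C(=O)N(CCCN2CCN(Cc3ccc(Cl)nc3)CC2)c2ccc(C)c(Cl)c2)CC1` differs from compound 2 by 6-chloropyridin-3-yl in place of pyridin-4-yl on a saturated chain carbon bound to an amine nitrogen in a ring. Among the measured compounds shown here, no measured step bears on this change, and all three values sit at a limit (the limit of > 56700 nM in this assay, at which 1 of the 3 values shown sits, among them). Compound 4 is therefore expected to remain at the limit, the step being estimated as an at least 1.0-fold lower number from compound 2 to compound 4 (0.00 log units; that floor lies within the scatter). The estimate for compound 4 in this assay is 56000 nM, within 20000 nM to 120000 nM.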

Compound 4, half-maximal cytotoxic concentration: > 53100 nM
Compound 4 ended at the assay's limit (the forecaster's own chance of this, stated with the estimate: 80%); the middle value does not contradict the limit.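

In this assay compound 4 gives > 53100 nM, a limit of the assay and not a number. Compound 2 also stands at a limit, and the step between compound 2 and compound 4 cannot be read. The compounds shown leave open how far any of their true cytotoxic concentrations lies past its limit.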